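A few compounds are considered here, and "the series" means these few. Any claim that something is new, unique, unknown or untested is made for them only; others in the source may bear on it.

Compound 1 `C[C@H](CCO)CC[C@@H]1[C@@]2(C)CCCC(C)(C)[C@@H]2CC[C@@]1(C)O` and compound 2 `CC(=O)OCC[C@@H](C)CC[C@@H]1[C@@]2(C)CCCC(C)(C)[C@@H]2CC[C@@]1(C)O` were both measured in a functional assay on RAW264.7 cells (Mus musculus) for inhibition, read by Griess assay, with stated times of 30 min and 24 h; on this read-out higher numbers stand for weaker inhibition and lower numbers for stronger inhibition. In this assay compound 1 gives 15000 nM, and compound 2 gives 15000 nM. The step of no change at the digits printed from compound 1 to compound 2 (within the scatter) shows that compound 2 stands level with compound 1. Compound 3 `C[C@H](CCOC(=O)c1ccc(Br)cc1)CC[C@@H]1[C@@]2(C)CCCC(C)(C)[C@@H]2CC[C@@]1(C)O` differs from compound 2 by 4-bromophenyl in place of methyl on a carbonyl carbon. Among the compounds with values here, the only step that bears on this change is the one from compound 1 to compound 2, which brought no change beyond the scatter, so a step of a 1.3-fold lower number from compound 2 to compound 3 (0.10 log units; within the scatter) is expected, with no clear direction. Compound 3 is therefore estimated at 12000 nM, within a range from 5000 nM to 30000 nM.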

Compound 3, half-maximal inhibitory concentration: > 50000 nM
Compound 3 ended at the assay's limit; the forecaster's own chance of this, stated with the estimate: 20%; middle value at least 4.1-fold (0.61 log units) away from the limit.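

In this assay, the oxygen on the saturated carbon is not indifferent to what it carries, although acetyl there had shown no change: 4-bromophenyl in place of methyl on a carbonyl carbon gives an at least 3.3-fold higher number from compound 2 to compound 3 (0.52 log units; beyond the scatter), and (4-bromophenyl)carbonyl in place of hydrogen gives an at least 3.3-fold higher number from compound 1 to compound 3 (0.52 log units; beyond the scatter). As far as these compounds go, compound 3 stands at a limit of the assay, not at a number: the limit of > 50000 nM in this assay, at which 1 of the 3 values shown sits. The full size of the weakening therefore stays unknown. The compounds shown leave open whether it goes with the bromine or with the aromatic ring, which a plain benzoyl or a longer acyl chain on that oxygen would separate.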